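The compounds below may be only part of what the source reports. "The series", "measured", "known", "first", "only" and "open" are said of these compounds alone.

Among the compounds with values here, in a functional assay on SMMC-7721 cells (Homo sapiens) for antiproliferative activity, read by MTT assay, with a stated time of 48 h (a higher number here means a weaker inhibitor, a lower number a stronger inhibitor), compound 1 `CCN(CC)C/C1=C/C[C@](C)(CCC=C(C)C)/C=C/[C@@H](OC(=O)C=C(C)C)[C@](C)(O)/C=C/C1=O` gives 570 nM and compound 2 `CSC(=S)OC/C1=C/C[C@](C)(CCC=C(C)C)/C=C/[C@@H](OC(=O)C=C(C)C)[C@](C)(O)/C=C/C1=O` gives 720 nM, so compound 2 stands level with the only other measured compound. Compound 3 `CO/N=C/C1=C/C[C@](C)(CCC=C(C)C)/C=C/[C@@H](OC(=O)C=C(C)C)[C@](C)(O)/C=C/C1=O` differs from compound 2 on a double-bonded ring carbon: a group of 4 heavy atoms (2 carbon, 1 nitrogen, 1 oxygen; no ring) in place of a group of 6 heavy atoms (3 carbon, 1 oxygen, 2 sulfur; no ring), on a double-bonded ring carbon. Within the data shown here, the only measured step, a 1.3-fold higher number from compound 1 to compound 2 (0.10 log units; within the scatter), exchanged one open-chain group for another, and it offers thin guidance for this new change. On that evidence, no shift beyond the scatter is expected in this assay. The estimated change is a 1.0-fold higher number from compound 2 to compound 3 (0.02 log units; within the scatter). The expected value for compound 3 is 750 nM, within an estimated range of 250 nM to 2300 nM.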

Compound 3, half-maximal inhibitory concentration: 3470 nM
The estimate for compound 3 lay 4.6-fold (0.67 log units) below the measured number, outside the stated range (above it).
By their numbers in this assay, from the lowest: compounds 1 and 2 (each within the scatter of the next); then compound 3.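

In this assay this double-bonded ring carbon does not tolerate every open-chain group equally: the exchange between compounds 1 and 2 stayed within the scatter, whereas a 4.8-fold higher number from compound 2 to compound 3 (0.68 log units; beyond the scatter) and a 6.1-fold higher number from compound 1 to compound 3 (0.78 log units; beyond the scatter) both lie beyond it. Two quite different groups thus stand level, and only the smaller group entering in compound 3 separates from them. Nothing measured here accounts for this shift.

Going by these compounds, whether a morpholine or a carboxylic acid at this carbon would stay level with compounds 1 and 2 or give a number nearer compound 3 remains open.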